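The compounds below may be only part of what the source reports. "The series", "measured", "known", "first", "only" and "open" are said of these compounds alone.

In a functional assay on HL-60 cells (Homo sapiens) for antiproliferative activity, with a stated time of 72 h (on this read-out higher numbers stand for weaker inhibition and lower numbers for stronger inhibition), compound 1 `COc1cccc(CNc2ncnc3c2ncn3[C@@H]2O[C@H](CO)[C@@H](O)[C@H]2O)c1OC` is reported only as a limit, > 166000 nM. Within the data shown here, compound 2 `OC[C@H]1O[C@@H](n2cnc3c(NCc4ccc(F)c(F)c4F)ncnc32)[C@H](O)[C@@H]1O` gives 13000 nM, the only actual number so far. Compound 3 `OC[C@H]1O[C@@H](n2cnc3c(NCc4ccc(F)c(Cl)c4)ncnc32)[C@H](O)[C@@H]1O` differs from it by 3-chloro-4-fluorophenyl in place of 2,3,4-trifluorophenyl on a saturated chain carbon bound to a nitrogen on an aromatic ring, with 3-chloro-4-fluorophenyl in place of 2,3,4-trifluorophenyl on a saturated chain carbon bound to a nitrogen on an aromatic ring. Among the measured compounds shown here, the one measured step, an at least 12-fold lower number from compound 1 to compound 2 (1.10 log units; beyond the scatter), was large, but it exchanged 2,3-dimethoxyphenyl for 2,3,4-trifluorophenyl, so it bears only loosely on this change. No shift beyond the scatter is therefore expected, and the estimated change is a 1.3-fold lower number from compound 2 to compound 3 (0.11 log units; within the scatter). Compound 3 is expected at 10000 nM, within an estimated range of 3000 nM to 35000 nM.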

Compound 3, half-maximal inhibitory concentration: 3500 nM
Beside the measured number, compound 3's estimate is 2.9-fold (0.46 log units) above it; the measured number falls inside the stated range.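

In this assay, the place on a saturated chain carbon bound to a nitrogen on an aromatic ring separates two halogen-bearing groups: 3-chloro-4-fluorophenyl in place of 2,3,4-trifluorophenyl gives a 3.7-fold lower number from compound 2 to compound 3 (0.57 log units; beyond the scatter). Set against 2,3-dimethoxyphenyl, 3-chloro-4-fluorophenyl gives an at least 47-fold lower number from compound 1 to compound 3 (1.67 log units; beyond the scatter), and this step rests on a limit for compound 1: the limit of > 166000 nM in this assay, at which 1 of the 3 values shown sits.

The compounds shown leave open whether the chlorine or the absent fluorines account for the shift. As far as these compounds go, how 3-bromo-4-fluorophenyl, or a longer chain carrying 3-chloro-4-fluorophenyl, would read also remains open.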